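Hydroxyindole Cap Replacing Thiophene in a Hydroxamate Series

This account rests on a few compounds, and the source may have more. Where it says the series, first, only, none or still open, it means among the compounds named here.

Compound 1, `O=C(CCCCC[C@H](NC(=O)c1ccc(Br)cc1)C(=O)NCc1ccccc1)NO`, 5860 nM in a functional assay on NFF cells (Homo sapiens) for antiproliferative activity; a lower number here means a stronger inhibitor, a higher number a weaker inhibitor.
Compound 2, `O=C(CCCCC[C@H](NC(=O)c1cccs1)C(=O)NCc1ccccc1)NO`, 5200 nM.

In this assay compound 2 has the lower of the two numbers, though its step from compound 1 is a 1.1-fold lower number from compound 1 to compound 2 (0.05 log units; within the scatter), so the two compounds cannot be told apart. Compound 3, `O=C(CCCCC[C@H](NC(=O)c1cc2c(O)cccc2[nH]1)C(=O)NCc1ccccc1)NO`, differs from compound 2 by 4-hydroxy-1H-indol-2-yl in place of thiophen-2-yl on a carbonyl carbon. Among the compounds with values here, the only measured step, a 1.1-fold lower number from compound 1 to compound 2 (0.05 log units; within the scatter), concerns a smaller aryl swap at the same carbonyl carbon and gives no direction. The entering group is larger and carries two donors, so an uncertain, modest change is expected: a 1.7-fold lower number from compound 2 to compound 3 (0.24 log units; within the scatter). Compound 3 is estimated at 3000 nM, between 800 nM and 10000 nM.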

Compound 3, half-maximal inhibitory concentration: 2210 nM
For compound 3 the middle estimate is 1.4-fold (0.13 log units) above the measured one; measured number inside the range.
By their numbers in this assay, from the lowest: compound 3; then compounds 2 and 1 (each within the scatter of the next).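

Within the data shown here, at this carbonyl carbon, 4-hydroxy-1H-indol-2-yl gives the first change in this assay that lies beyond the scatter, with a 2.4-fold lower number from compound 2 to compound 3 (0.37 log units; beyond the scatter) and a 2.7-fold lower number from compound 1 to compound 3 (0.42 log units; beyond the scatter) while thiophen-2-yl and 4-bromophenyl could not be told apart. The number at this position therefore does respond to the group on the carbonyl carbon, though only modestly. Nothing available explains this difference. The compounds shown leave open whether the step belongs to the hydroxyl or to the indole itself. The unsubstituted 1H-indol-2-yl group or a methoxy in place of the hydroxyl would separate the two.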